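Methyl on the Ring Amine of Compound 3

This account rests on a few compounds, and the source may have more. Where it says the series, first, only, none or still open, it means among the compounds named here.

Compound 3 `C1=C(c2cccnc2)C[C@@H]2CNC[C@H]1C2` gives 0.1 nM in an in vitro assay on SH-EP1 cells for displacement of a labelled ligand from Neuronal acetylcholine receptor; alpha4/beta2 (Homo sapiens) (a lower number here means a stronger inhibitor, a higher number a weaker inhibitor), the lowest of the three numbers recorded. Its nearest neighbour is compound 2 `C1=C(c2cccnc2)C[C@H]2CNC[C@@H]1C2`, which gives 0.2 nM in this assay; the step of a 2.0-fold lower number from compound 2 to compound 3 (0.30 log units; within the scatter) is within the scatter, and the fact that compounds 2 and 3 differ only in the configuration as drawn is the only difference between them. Furthest away is compound 1 `CN1C[C@H]2C=C(c3cccnc3)C[C@H](C2)C1`, which gives 2.1 nM in this assay, and the step of an 11-fold lower number from compound 1 to compound 2 (1.02 log units; beyond the scatter) is large and well beyond the scatter.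

Compound 4 `CN1C[C@@H]2C=C(c3cccnc3)C[C@@H](C2)C1` differs from compound 3 in one place: methyl in place of hydrogen on an amine nitrogen in a ring. Within the data shown here, the one measured step that bears on this change is an 11-fold lower number from compound 1 to compound 2 (1.02 log units; beyond the scatter), which is the same exchange run in the opposite direction. Since the two enantiomeric cores behave alike in this assay, the same exchange in the opposite direction is expected to be of similar size toward a higher number, estimated at about an 11-fold higher number from compound 3 to compound 4 (1.04 log units; beyond the scatter). Compound 4 is therefore estimated to give 1.1 nM in this assay, with a likely range of 0.4 nM to 3.5 nM.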

Compound 4, inhibition constant: 9.4 nM
Estimate against measurement, compound 4: 8.5-fold (0.93 log units) below; the whole stated range lies below it.
By their numbers in this assay, from the lowest: compounds 3 and 2 (each within the scatter of the next); then compound 1; then compound 4.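

Methyl in place of hydrogen on an amine nitrogen in a ring has no single effect in this assay, where the step on this core is a 94-fold higher number from compound 3 to compound 4 (1.97 log units; beyond the scatter). Its size depends on which mirror-image core carries it: the same change on two cores in this assay, an 11-fold lower number (1.02 log units; beyond the scatter) from compound 1 to compound 2 and a 94-fold lower number (1.97 log units; beyond the scatter) from compound 4 to compound 3, 9.0-fold (0.95 log units) apart, beyond the scatter of two such steps. Inverting all stereocentres left the two compounds with hydrogen on that nitrogen within the scatter of each other, but with methyl there it gives a 4.5-fold higher number from compound 1 to compound 4 (0.65 log units; beyond the scatter): the fact that compounds 1 and 4 differ only in the configuration as drawn.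

The compounds shown leave open whether the two mirror-image cores would separate further with ethyl or a longer chain on that nitrogen, or with an acetyl group there. They also leave open whether the same dependence on configuration would appear at any other receptor.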